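Ester to methyl ketone at the carbonyl carbon

A few compounds are considered here, and "the series" means these few. Any claim that something is new, unique, unknown or untested is made for them only; others in the source may bear on it.

Measured so far in an assay on membranes from HeLa cells for displacement of a labelled ligand from adenosine receptor A3 (Homo sapiens), read by scintillation counting, with a stated time of 180 min, tested at 1 uM; a higher number here means more inhibition at the concentration tested (going by the name of the read-out), a lower number less inhibition:
compound 1 `CCCOC(=O)C1=C(C)NC(=O)NC1c1ccoc1` gives 11%
compound 2 `CC1=C(C(=O)OCC(C)C)C(c2ccoc2)NC(=O)N1` gives 16%

Going by the values given here, compound 2 carries the higher of the two numbers, but its only neighbour is compound 1, and the step of a number 5 percentage points higher from compound 1 to compound 2 (within the scatter) stays within the scatter, so the two cannot be ordered and their numbers count as level at the tested concentration.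

Compound 3 `CC(=O)C1=C(C)NC(=O)NC1c1ccoc1` has not been measured. Its change from compound 2 is methyl in place of isobutoxy on a carbonyl carbon. Among the compounds with values here, the only measured step, from compound 1 to compound 2, alters the alkyl part of the ester and leaves the carbonyl and its oxygen untouched; it says nothing about what happens when the isobutoxy is removed and a methyl is left on the carbonyl carbon. Within the data shown here, no measured pair bears on that exchange.

Among the measured compounds shown here, with no step to rest on, the number for compound 3 is expected to stay level with what has been measured so far, so the step of a number 4 percentage points lower from compound 2 to compound 3 (within the scatter) is expected to be nothing beyond the scatter. The estimate for compound 3 is 12%, within 0% to 30%.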

Compound 3, a percentage reported as inhibition, at one concentration (the size of the read-out at that concentration, not a potency): 2%
Beside the measured number, compound 3's estimate is 10 percentage points above it; low and high end bracket the measured number.
By their numbers in this assay, from the lowest: compounds 3, 1 and 2 (each within the scatter of the next, the first and the last beyond it).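

In this assay, going by these compounds alone, the exchange at the carbonyl carbon is the first change to give a step beyond the scatter: methyl in place of isobutoxy gives a number 14 percentage points lower from compound 2 to compound 3 (beyond the scatter), whereas the earlier step altered only the alkyl part of the ester and stayed within the scatter. The same exchange made from the propoxy ester gives a number 9 percentage points lower from compound 1 to compound 3 (within the scatter), so the effect of removing the alkoxy group at this position is clear from only one of the two esters, and the series does not yet support a general rule for this exchange. Nothing available explains why the number moves with this exchange.

Going by these compounds, it remains open whether the loss of the ester oxygen or the shortening of the group on the carbonyl carbon accounts for the step, and a ketone bearing an isobutyl chain would help separate the two. Also open is how an amide or a carboxylic acid at this carbonyl carbon would read, and with single-concentration percentages alone, the series offers no potency for any of these compounds.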